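Swapping Halogens on the Benzyl Arm of a Nucleoside

A few compounds are considered here, and "the series" means these few. Any claim that something is new, unique, unknown or untested is made for them only; others in the source may bear on it.

Of the compounds shown here, two have been tested so far. Compound 1 `OC[C@H]1O[C@@H](n2cnc3c(NCc4ccc(Br)cc4)ncnc32)[C@H](O)[C@@H]1O` carries a 4-bromophenyl group on a saturated chain carbon bound to a nitrogen on an aromatic ring. In a functional assay on B16 cells (Mus musculus) for antiproliferative activity, with a stated time of 72 h (a higher number here means a weaker inhibitor, a lower number a stronger inhibitor), compound 1 gives > 166000 nM, which is a limit of the assay rather than a number. Compound 2 `OC[C@H]1O[C@@H](n2cnc3c(NCc4ccc(Cl)cc4Cl)ncnc32)[C@H](O)[C@@H]1O` carries a 2,4-dichlorophenyl group at the same place. In this assay compound 2 gives > 166000 nM, again a limit and not a number. From the compounds shown here alone, the step that the two limits leave unreadable from compound 1 to compound 2 therefore cannot be read, and its size stays unknown. Compound 2 stands where both measured compounds stand, at the limit of > 166000 nM in this assay, at which 2 of the 2 values shown sit.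

Compound 3 `OC[C@H]1O[C@@H](n2cnc3c(NCc4ccc(F)c(Cl)c4)ncnc32)[C@H](O)[C@@H]1O` differs from compound 2 in one place: 3-chloro-4-fluorophenyl in place of 2,4-dichlorophenyl on a saturated chain carbon bound to a nitrogen on an aromatic ring. Within the data shown here, no measured step can guide this change in size or direction, since the only step between measured compounds is unreadable. What can be said is that both measured compounds sit at the same limit, so the step that the limit leaves unreadable from compound 2 to compound 3 is expected to leave compound 3 at that same limit as well. Compound 3 is therefore estimated at 200000 nM, with a range from 80000 nM to 600000 nM.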

Compound 3, half-maximal inhibitory concentration: 167000 nM
For compound 3 the middle estimate is 1.2-fold (0.08 log units) above the measured one; measured number inside the range.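

The steps from compound 1 to compound 3 and from compound 2 to compound 3 cannot be read, because compounds 1 and 2 each give only a limit of the assay and not a number: the limit of > 166000 nM in this assay, at which 2 of the 3 values shown sit.

The compounds shown leave open whether any group at this place on the shared core would give a clearly lower number in this assay.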